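The compounds below may be only part of what the source reports. "The series", "measured", "known", "first", "only" and "open" are said of these compounds alone.

Compound 1 `NC(=O)c1cc(-c2ccccc2)cc2c(C3CCN(S(=O)(=O)CCCNC4CCCC4)CC3)c[nH]c12` gives 140 nm/s
Compound 2 `NC(=O)c1cc(-c2ccccc2)cc2c(C3CCN(S(=O)(=O)CCCN4CCCCC4)CC3)c[nH]c12` gives 240 nm/s
Compound 3 `NC(=O)c1cc(-c2ccccc2)cc2c(C3CCN(S(=O)(=O)CCCN4CCCC4)CC3)c[nH]c12` gives 160 nm/s

These numbers come from an ADME assay for permeability, using PAMPA; a lower number here means that the compound crosses the layer more slowly, a higher number that the compound crosses the layer faster. The three compounds share one core and differ only in the group at the end of the chain on the sulfonyl. Compound 3, with 160 nm/s in this list, sits within the scatter of both compound 1 and compound 2, so it holds no distinct place among them.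

Compound 4 `CCN(CC)CCCS(=O)(=O)N1CCC(c2c[nH]c3c(C(N)=O)cc(-c4ccccc4)cc23)CC1` has not been measured yet. It differs from compound 3 in one place (diethylamino in place of pyrrolidin-1-yl on a saturated chain carbon, three bonds along the chain from a sulfonyl sulfur), with diethylamino in place of pyrrolidin-1-yl on a saturated chain carbon, three bonds along the chain from a sulfonyl sulfur. The entering group has no ring.

Three measured steps swap one group for another at this same place (a 1.7-fold higher number from compound 1 to compound 2 (0.23 log units; within the scatter)) (a 1.1-fold higher number from compound 1 to compound 3 (0.06 log units; within the scatter)) (a 1.5-fold lower number from compound 2 to compound 3 (0.18 log units; within the scatter)), and all of them lie within the scatter. Among the measured compounds shown here, every group in those steps carries a ring, so no measured compound shows an open-chain group here, which makes the forecast less firm. In this assay no step beyond the scatter is expected, in either direction. The expected step, an estimate only, is small (a 1.2-fold higher number from compound 3 to compound 4 (0.07 log units; within the scatter)). For compound 4 the estimated value is 190 nm/s with an expected range from 100 nm/s to 360 nm/s in repeat measurements.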

Compound 4, apparent permeability in the ADME assay: 200 nm/s
Beside the measured number, compound 4's estimate is 1.1-fold (0.02 log units) below it; the range from low to high includes it.
By their numbers in the ADME assay, from the lowest: compounds 1, 3, 4 and 2 (each within the scatter of the next).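

Among the compounds shown here, every group at this place in the earlier compounds carried a ring, and in the ADME assay compound 4 (200 nm/s) shows that the open-chain diethylamino group can stand there with no step beyond the scatter (a 1.3-fold higher number from compound 3 to compound 4 (0.10 log units; within the scatter)) (a 1.2-fold lower number from compound 2 to compound 4 (0.08 log units; within the scatter)) (a 1.4-fold higher number from compound 1 to compound 4 (0.15 log units; within the scatter)). Opening the ring of pyrrolidin-1-yl to give diethylamino, which holds the same number of carbon and nitrogen atoms, also stays within the scatter in a physicochemical assay for solubility, read by HPLC, measured as kinetic solubility; a higher number here means a more soluble compound, a lower number a less soluble compound (compound 3 gives 185000 nM and compound 4 gives 173000 nM) (a 1.1-fold lower number from compound 3 to compound 4 (0.03 log units; within the scatter)), so among these compounds the ring is not required to keep either read-out where it stands. No measurement offered here explains why the numbers stay so close together.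

Diethylamino is the only open-chain group shown, so one compound cannot tell whether another open-chain amine such as diisopropylamino would behave the same way. Every compound also ends in an amine on the same propyl chain, which leaves open what a morpholine ring, a carboxylic acid or a longer chain at this place would do to these two read-outs.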